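Benzamido in Place of Hydrogen on Compound 1

The source may hold more compounds than are shown below. What is called first, only, known or untested is meant among the compounds shown, and "the series" means these compounds.

Measured compounds:
compound 1 `CCOc1ccc(NCN2C(=O)c3ccccc3C2=O)cc1` — 100%
compound 2 `CCOc1ccc(NCN2C(=O)c3ccc([N+](=O)[O-])cc3C2=O)cc1` — 87%

In an assay on isolated protein for inhibition of ribosomal protein S6 kinase alpha-2 (Homo sapiens), read by fluorescence, with a stated time of 20 min, tested at 10 uM (a lower number here means less inhibition, a higher number more inhibition at the concentration tested (going by the name of the read-out)), compound 1 gives 100%, the highest of the two numbers; its nearest neighbour is compound 2, with a number 13 percentage points lower from compound 1 to compound 2 (beyond the scatter). Compound 3 `CCOc1ccc(NCN2C(=O)c3cccc(NC(=O)c4ccccc4)c3C2=O)cc1` differs from compound 1 by benzamido in place of hydrogen on an aromatic carbon. Within the data shown here, only one measured step bears on this change: the substitution of an aromatic carbon on the same fused ring, which gave a number 13 percentage points lower from compound 1 to compound 2 (beyond the scatter), a modest fall beyond the scatter. Because that step a number 13 percentage points lower from compound 1 to compound 2 (beyond the scatter) concerns a different group at a different place, it is only a loose guide here. Compound 3 is therefore expected to stay close to compound 1, with at most a modest fall, so that a number 15 percentage points lower from compound 1 to compound 3 (beyond the scatter) is estimated. Compound 3 is expected to give 85%, within a range from 55% to 100% in this assay.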

Compound 3, a percentage reported as inhibition, at one concentration (the size of the read-out at that concentration, not a potency): 105%
For compound 3 the middle estimate is 20 percentage points below the measured one; measured number outside the range, above it.
By their numbers in this assay, from the lowest: compound 2; then compounds 1 and 3 (each within the scatter of the next).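

In this assay, benzamido on this aromatic carbon, ortho to a fused ring and meta to a fused ring, leaves the read-out unchanged within the scatter, with a number 5 percentage points higher from compound 1 to compound 3 (within the scatter). The position therefore accepts an added six-membered aromatic ring, joined through an amide, without a measurable loss of inhibition at the concentration tested, so the earlier fall seen with nitro, a number 13 percentage points lower from compound 1 to compound 2 (beyond the scatter), does not extend to this change. No measurement shown gives a reason for this outcome.

Going by these compounds, it remains open whether an amine or an acetamido group on the same aromatic carbon would also hold the read-out. Also open, on these data alone, is whether potency differs between compound 1 and compound 3, since a percentage at one concentration does not give a potency.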